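A few compounds are considered here, and "the series" means these few. Any claim that something is new, unique, unknown or untested is made for them only; others in the source may bear on it.

Working notes on the series

The series shares one core; compound 1 `COc1cc(-c2cc(/C=C/C(=O)c3ccc(N)cc3)[nH]n2)cc(OC)c1OC`, compound 2 `COc1ccc(C(=O)/C=C/c2cc(-c3cc(OC)c(OC)c(OC)c3)n[nH]2)cc1OC` and compound 3 `COc1ccc(C(=O)/C=C/c2cc(-c3cc(OC)c(OC)c(OC)c3)n[nH]2)cc1` have been measured in a functional assay on NCI-H522 cells (Homo sapiens) for cytotoxicity, read by sulforhodamine B assay, with a stated time of 48 h, tested at 1 uM; a lower number here means a stronger effect, a higher number a weaker effect of the compound at the concentration tested. In this assay compound 1 gives 77%, compound 2 gives -63% and compound 3 gives 75%. The two cores differ as described by 4-aminophenyl in place of 3,4-dimethoxyphenyl on a carbonyl carbon, a change that produced a number 140 percentage points lower from compound 1 to compound 2 (beyond the scatter). Replacing amino by methoxy gave a number 2 percentage points lower from compound 1 to compound 3 (within the scatter), so compound 1 and compound 3 cannot be ordered against each other.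

The change of interest, hydrogen in place of methoxy on an aromatic carbon, has been measured once, from compound 2 to compound 3: hydrogen in place of methoxy on an aromatic carbon. That step was a number 138 percentage points higher from compound 2 to compound 3 (beyond the scatter). The same kind of change is now made from compound 1 to compound 4 `COc1ccc(-c2cc(/C=C/C(=O)c3ccc(N)cc3)[nH]n2)cc1OC`: hydrogen in place of methoxy on an aromatic carbon. Around the place the two differ: in compound 4 the carbon is also meta to a methoxy group, whereas in compound 3 it is not, so this is the same kind of change, not the same change.

The large earlier step started from a strongly negative number in compound 2. Compound 1 already stands at 77%, the highest of the three, which leaves little room for a comparable rise; a step of the earlier size cannot be reproduced from there. For compound 4 the expected step is a number 7 percentage points higher from compound 1 to compound 4 (within the scatter), small beside the earlier one, because compound 1 sits at 77%. Compound 4 is therefore estimated at 84%, with a range from 62% to 104%.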

Compound 4, a percentage reported as activity, at one concentration (the size of the read-out at that concentration, not a potency): 87%
The estimate for compound 4 lay 3 percentage points below the measured number; low and high end bracket the measured number.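

In this assay, hydrogen in place of methoxy on the core of compound 1 gave a number 10 percentage points higher from compound 1 to compound 4 (within the scatter), and this step does not match the one seen on the other core: the same change on two cores in this assay, a number 138 percentage points higher (beyond the scatter) from compound 2 to compound 3 and a number 10 percentage points higher (within the scatter) from compound 1 to compound 4, 128 percentage points apart, beyond the scatter of two such steps The change therefore does not carry its size from one core to the other in this series, and on the core of compound 1 the two compounds cannot be ordered against each other. This does not show which difference accounts for the gap, since it rests on one pair against one pair, the two cores carry different groups on the carbonyl carbon, and the changed carbon is meta to a methoxy group in compound 4 but not in compound 3.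

As far as these compounds go, it remains open whether the strong effect of compound 2, at -63%, is tied to the 3,4-dimethoxyphenyl group on the carbonyl carbon together with its full set of methoxy groups, or would survive other replacements there. From the compounds shown here alone, it also remains open whether a hydroxy group, an ethoxy group or a fluorine atom on the same aromatic carbon would move the read-out on either core, where hydrogen and methoxy have so far given such different outcomes.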